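From Bromophenyl to Difluorophenyl: A Swap on the Shared Core

A few compounds are considered here, and "the series" means these few. Any claim that something is new, unique, unknown or untested is made for them only; others in the source may bear on it.

Measured so far:
compound 1 `C=C(C)c1cn(-c2cccc(C(=O)/C=C/c3ccc(O)c(OC)c3)c2)nn1`: 9790 nM
compound 2 `COc1cc(/C=C/C(=O)c2cccc(-n3cc(-c4ccc(Br)cc4)nn3)c2)ccc1O`: 19100 nM

In a functional assay on RAW264.7 cells (Mus musculus) for inhibition, with a stated time of 4 days (a higher number here means a weaker inhibitor, a lower number a stronger inhibitor), compound 2 gives 19100 nM, the higher of the two numbers measured, while compound 1 gives 9790 nM. For the measured compounds named here, the only step between them, a 2.0-fold higher number from compound 1 to compound 2 (0.29 log units; within the scatter), stays within the scatter, so the two compounds cannot be ranked against each other on these figures.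

Going by the values given here, compound 3 `COc1cc(/C=C/C(=O)c2cccc(-n3cc(-c4cc(F)cc(F)c4)nn3)c2)ccc1O` keeps the core of compound 2 and changes only one group: 3,5-difluorophenyl in place of 4-bromophenyl on an aromatic carbon. Among the compounds with values here, no measured step involves this exact change. Within the data shown here, the single step on record, a 2.0-fold higher number from compound 1 to compound 2 (0.29 log units; within the scatter), concerns a different group at the same position, and it did not move the number beyond the scatter. With such a small and indirect precedent, no clear direction can be drawn, and the expected step of a 1.3-fold lower number from compound 2 to compound 3 (0.10 log units; within the scatter) is accordingly one that stays within the scatter.

On this basis compound 3 is estimated to give 15000 nM in this assay, with a likely range from 5000 nM to 45000 nM.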

Compound 3, half-maximal inhibitory concentration: 22800 nM
Estimate against measurement, compound 3: 1.5-fold (0.18 log units) below; low and high end bracket the measured number.
By their numbers in this assay, from the lowest: compounds 1, 2 and 3 (each within the scatter of the next, the first and the last beyond it).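

In this assay, the change from 4-bromophenyl to 3,5-difluorophenyl on this aromatic carbon gives a 1.2-fold higher number from compound 2 to compound 3 (0.08 log units; within the scatter) and so does not separate the two phenyl groups, even though the ring now carries two fluorines in different places instead of one bromine. For the compounds shown here, the comparison with the small 1-methylethenyl group is where something new appears: 3,5-difluorophenyl in place of that group gives a 2.3-fold higher number from compound 1 to compound 3 (0.37 log units; beyond the scatter) and is the first step at this position to clear the scatter, a modest loss of inhibition that makes compound 3 a weaker inhibitor than compound 1. This does not establish that a phenyl group here costs inhibition, since compound 2 also carries one and goes against that reading by staying within the scatter of compound 1, and nothing available offers an explanation for these numbers.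

The compounds shown leave open whether an amine or a carboxylic acid on the phenyl ring, or a longer alkyl chain in its place, would move the number further in either direction. They also leave open how a change elsewhere on the shared core would compare with these changes on the aromatic carbon.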